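A few compounds are considered here, and "the series" means these few. Any claim that something is new, unique, unknown or untested is made for them only; others in the source may bear on it.

Measured so far:
compound 1 `Cn1c(-c2ccc(NC(=O)CSc3nc4cc(Cl)ccc4o3)cc2)nc(-c2ccccc2)c1-c1ccccc1`: 69.1%
compound 2 `CN(C)/C=C/N1CCN(CC(=O)Nc2ccc(-c3nc(-c4ccccc4)c(-c4ccccc4)n3C)cc2)CC1`: 34.7%

Among the compounds with values here, in a functional assay on MCF7 cells (Homo sapiens) for cytotoxicity, read by MTT assay, with a stated time of 24 h, tested at 80 ug/mL (on this read-out lower numbers stand for a weaker effect and higher numbers for a stronger effect at the one concentration tested), compound 2 stands lowest of the two numbers, with compound 1 the nearest and the only comparison. Within the data shown here, the one measured step, a number 34.4 percentage points lower from compound 1 to compound 2 (beyond the scatter), was large, but it exchanged the whole arm on the saturated chain carbon bound to the carbonyl carbon. Compound 3 `Cn1c(-c2ccc(NC(=O)CN3CCN(c4ccccc4)CC3)cc2)nc(-c2ccccc2)c1-c1ccccc1` differs from compound 2 by phenyl in place of 2-(dimethylamino)ethenyl on an amine nitrogen in a ring. Among the measured compounds shown here, no measured step bears on the group on the amine nitrogen in the ring, so the direction is open and the expectation stays close to compound 2 with wide margins. Compound 3 is expected at 42% (range 20% to 65%), an estimated step of a number 7.3 percentage points higher from compound 2 to compound 3 (within the scatter).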

Compound 3, a percentage reported as activity, at one concentration (the size of the read-out at that concentration, not a potency): 72.5%
For compound 3 the middle estimate is 30.5 percentage points below the measured one, outside the stated range (above it).
By their numbers in this assay, from the lowest: compound 2; then compounds 1 and 3 (each within the scatter of the next).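

On the amine nitrogen in the ring, the group decides the reading in this assay: phenyl in place of 2-(dimethylamino)ethenyl gives a number 37.8 percentage points higher from compound 2 to compound 3 (beyond the scatter), so the low value of compound 2 goes with that group and not with the ring that carries it. The 4-phenylpiperazin-1-yl and (5-chloro-1,3-benzoxazol-2-yl)sulfanyl arms do not separate, with a number 3.4 percentage points higher from compound 1 to compound 3 (within the scatter). No measurement given here explains the effect of the phenyl group. From the compounds shown here alone, it remains open whether a benzyl group or a simple methyl on that nitrogen would match phenyl. A chlorine or methoxy group on the phenyl ring is equally untested in this account.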